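The compounds below may be only part of what the source reports. "The series", "measured", "known", "first", "only" and "open" are said of these compounds alone.

In a functional assay on T47D cells (Homo sapiens) for antiproliferative activity, read by MTT assay, with a stated time of 72 h (on this read-out lower numbers stand for stronger inhibition and higher numbers for weaker inhibition), compound 1 (`COc1ccc(-n2ccnc2-c2cc(OC)c(OC)c(OC)c2)cc1[N+](=O)[O-]`) gives 10000 nM. Compound 2 (`COc1cc(-c2nccn2-c2cccc([N+](=O)[O-])c2)cc(OC)c1OC`), with hydrogen in place of methoxy on an aromatic carbon, gives 17900 nM. Among the compounds with values here, these two numbers do not separate, since the measured change is a 1.8-fold higher number from compound 1 to compound 2 (0.25 log units; within the scatter), so compound 1 stands within the scatter of its only measured neighbour.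

Compound 3 (`COc1ccc(-n2ccnc2-c2cc(OC)c(OC)c(OC)c2)cc1N`) is compound 1 with amino in place of nitro on an aromatic carbon, and the exchange is counted as amino in place of nitro on an aromatic carbon. That one measured step concerns a methoxy group, and both of its compounds keep the nitro, so it gives no direct measure of the new exchange. Within the data shown here, no measured compound here carries the amino group, and the data therefore do not fix the size of the step. A moderate move towards a lower number in this assay is nevertheless expected, held loosely, with a range wide enough to include no change at all. The expected step is a 3.3-fold lower number from compound 1 to compound 3 (0.52 log units; beyond the scatter). For compound 3 the estimated value is 3000 nM, with an expected range from 150 nM to 20000 nM.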

Compound 3, half-maximal inhibitory concentration: 500 nM
Beside the measured number, compound 3's estimate is 6.0-fold (0.78 log units) above it; low and high end bracket the measured number.
By their numbers in this assay, from the lowest: compound 3; then compounds 1 and 2 (each within the scatter of the next).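

In this assay, the exchange of nitro for amino, on an aromatic carbon ortho to a methoxy group and meta to a large group, gives a 20-fold lower number from compound 1 to compound 3 (1.30 log units; beyond the scatter) and is the first step among these compounds to lie beyond the scatter. Within the data shown here, the earlier step concerned the methoxy group and stayed within the scatter (a 1.8-fold higher number from compound 1 to compound 2 (0.25 log units; within the scatter)), so only this new step shows that the number in this assay responds to what sits at this position. The exchange replaces 3 heavy atoms with 1 and brings in 1 hydrogen-bond donor where nitro has 0, but nothing measured here says which feature of the change, if either, accounts for the step.

The compounds shown leave open how a hydroxyl, a methylamino group or an acetamide would read at this position, and so how far the step depends on the amino group itself rather than on the loss of nitro. They also leave open whether amino gives a step of this size on the core of compound 2, which has hydrogen in place of the methoxy group.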